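Swapping the Carboxyphenyl Group: What Compound 4 May Show

A few compounds are considered here, and "the series" means these few. Any claim that something is new, unique, unknown or untested is made for them only; others in the source may bear on it.

Compound 1 `Cc1c(OCCCCOc2ccc(C(=O)O)cc2Cl)ccc(C(=O)CC2CCCC2)c1O`: 120%
Compound 2 `Cc1c(OCCCCOc2cccc(C(=O)O)c2)ccc(C(=O)CC2CCCC2)c1O`: 99%
Compound 3 `Cc1c(OCCCCOc2ccc(C(=O)O)c(Cl)c2)ccc(C(=O)CC2CCCC2)c1O`: 97%

In an ADME assay on a cell-free system (plasma, Rattus norvegicus) for metabolic stability, read by LC-MS, with a stated time of 60 min, tested at 100 uM (on this read-out higher numbers stand for a more stable compound and lower numbers for a less stable compound), compound 3 gives 97%, level with compound 2 at 99% and clearly under compound 1 at 120%.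

Compound 4 `Cc1cc(C(=O)O)ccc1OCCCCOc1ccc(C(=O)CC2CCCC2)c(O)c1C` keeps the shared core and the chain of compound 3 and alters one group: 4-carboxy-2-methylphenyl in place of 4-carboxy-3-chlorophenyl on an oxygen on a saturated carbon. It carries 4-carboxy-2-methylphenyl in place of 4-carboxy-3-chlorophenyl.

All three measured steps changed this same group. Two were modest, a number 21 percentage points lower from compound 1 to compound 2 (beyond the scatter) and a number 23 percentage points lower from compound 1 to compound 3 (beyond the scatter), while a number 2 percentage points lower from compound 2 to compound 3 (within the scatter) stayed within the scatter. Among the measured compounds shown here, no measured compound carries the methyl group, so these steps offer only a rough guide. The closest name is the 4-carboxy-2-chlorophenyl of compound 1 at 120%, which suggests a small rise at most. The expected result is a number 8 percentage points higher from compound 3 to compound 4 (within the scatter), so no step beyond the scatter is expected.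

For compound 4 the estimated value is 105%, with an expected range from 88% to 122%.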

Compound 4, percent of the compound remaining: 99%
For compound 4 the middle estimate is 6 percentage points above the measured one, and the stated range covers the measured number.
By their numbers in this assay, from the lowest: compounds 3, 2 and 4 (each within the scatter of the next); then compound 1.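

In this assay the new group makes no difference that can be told from the scatter: the result is a number 2 percentage points higher from compound 3 to compound 4 (within the scatter) and no change at the digits printed from compound 2 to compound 4 (within the scatter) for this swap of the ring on the oxygen. Methyl in place of chloro on an aromatic carbon gives a number 21 percentage points lower from compound 1 to compound 4 (beyond the scatter) and is the one change here that isolates that single group, so 4-carboxy-2-methylphenyl does not share the higher number seen with 4-carboxy-2-chlorophenyl. Nothing measured here bears on why these two groups part in this way.

As far as these compounds go, it remains open whether fluoro, methoxy or trifluoromethyl in place of the methyl would read like compound 1 or like the other three compounds. Also open, from the compounds shown here alone, is what an amide or a tetrazole in place of the carboxylic acid would do to this read-out.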